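Oxathiazolone and dithiazolone aryl series: inhibition on liver cells

The compounds below may be only part of what the source reports. "The series", "measured", "known", "first", "only" and "open" are said of these compounds alone.

Measured so far:
compound 1 `O=c1nc(-c2cc(F)c(Cl)nc2Cl)ss1` gives 24.3% in an ADME assay on L02 cells (Homo sapiens) for inhibition, read by MTT assay, with a stated time of 48 h, tested at 100 uM; a higher number here means more inhibition at the concentration tested (going by the name of the read-out), a lower number less inhibition
compound 2 `O=c1oc(-c2ccccc2Cl)ns1` gives 20.6% in this assay
compound 3 `O=c1oc(-c2ccccc2[N+](=O)[O-])ns1` gives 32.4% in this assay

Compound 3 carries the highest number of the three, though its gap to compound 1 lies within the scatter; only compound 2 sits clearly lower. For the measured compounds named here, the one step recorded within the set, a number 11.8 percentage points higher from compound 2 to compound 3 (beyond the scatter), is the single clue to how a substituent on the six-membered aromatic ring of carbon only moves the read-out.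

Compound 4 `Cc1ccccc1-c1nsc(=O)o1` is the next member to be measured. It differs from compound 3 as follows: methyl in place of nitro on an aromatic carbon

The relevant comparison is the step from compound 2 to compound 3, where nitro in place of chloro raised the number modestly. Going the other way, from nitro to a small substituent without hydrogen-bond acceptors, the expectation is a drop of similar size, back toward the level of compound 2 and compound 1. For compound 4 the expected step in this assay is therefore a number 10.4 percentage points lower from compound 3 to compound 4 (beyond the scatter). Compound 4 is estimated at 22%, with a range from 10% to 34%.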

Compound 4, a percentage reported as inhibition, at one concentration (the size of the read-out at that concentration, not a potency): 18.1%
Estimate against measurement, compound 4: 3.9 percentage points above, within the range that was stated.
By their numbers in this assay, from the lowest: compounds 4, 2, 1 and 3 (each within the scatter of the next, the first and the last beyond it).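

Working notes on the ortho position: at this aromatic carbon, ortho to a group of 6 heavy atoms, methyl in place of nitro gives a number 14.3 percentage points lower from compound 3 to compound 4 (beyond the scatter) in this assay. Methyl in place of chloro gives a number 2.5 percentage points lower from compound 2 to compound 4 (within the scatter), so methyl and chloro cannot be told apart here, and among the three groups tried at this place, only nitro stands clear of the other two. No measurement at hand offers an explanation for the nitro result.

Still open, on these data alone, is whether nitro is alone in this or whether other groups at this place, such as an amine, a methoxy or a carboxylic acid, would match it. Also open, as far as these compounds go, is whether these steps would carry over to the core of compound 1.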